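The compounds below may be only part of what the source reports. "The series", "measured", "known", "first", "only" and "open" are said of these compounds alone.

Compound 1 `O=C(NO)c1ccc(CNC(=O)c2n[nH]cc2NC(=O)c2c(Cl)cccc2Cl)cc1`: 14600 nM
Compound 2 `Nc1ccccc1NC(=O)c1ccc(CNC(=O)c2n[nH]cc2NC(=O)c2c(Cl)cccc2Cl)cc1`: 7760 nM
Compound 3 `COc1ccccc1C(=O)Nc1c[nH]nc1C(=O)NCc1ccc(C(=O)Nc2ccccc2N)cc1`: 8320 nM

These numbers come from a functional assay on SMMC-7721 cells (Homo sapiens) for inhibition, read by CCK-8 assay, with a stated time of 72 h (a lower number here means a stronger inhibitor, a higher number a weaker inhibitor), and the three compounds lie within the scatter of one another, so compound 1 cannot be ranked apart from the other two. Compound 4 `O=C(NO)c1ccc(CNC(=O)c2n[nH]cc2NC(=O)c2ccccc2Cl)cc1` is compound 1 with a single change: hydrogen in place of chloro on an aromatic carbon in which hydrogen takes the place of chloro on an aromatic carbon, turning 2,6-dichlorophenyl into 2-chlorophenyl. Going by the values given here, no measured step removes a chlorine alone. The closest evidence is a 1.1-fold higher number from compound 2 to compound 3 (0.03 log units; within the scatter) where 2,6-dichlorophenyl gives way to 2-methoxyphenyl. The other step of a 1.9-fold lower number from compound 1 to compound 2 (0.27 log units; within the scatter) concerns a different part of the molecule, with 2-aminophenyl in place of hydroxy. Neither step goes beyond the scatter, so a shift in either direction is not expected here. The expected change is a 1.1-fold lower number from compound 1 to compound 4 (0.05 log units; within the scatter) and it stays inside the usual noise of the measurement. For compound 4 the estimated value is 13000 nM with an expected range from 6500 nM to 27000 nM.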

Compound 4, half-maximal inhibitory concentration: 21800 nM
Beside the measured number, compound 4's estimate is 1.7-fold (0.22 log units) below it, and the stated range covers the measured number.
By their numbers in this assay, from the lowest: compounds 2, 3, 1 and 4 (each within the scatter of the next, the first and the last beyond it).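

Compound 1 and compound 4 differ only in one chloro group on the aromatic ring, which hydrogen replaces to turn 2,6-dichlorophenyl into 2-chlorophenyl. In this assay, going by these compounds alone, this gives a 1.5-fold higher number from compound 1 to compound 4 (0.17 log units; within the scatter), so this single swap, unlike the earlier steps that changed the whole substituent or another part of the molecule, is now tested directly, and the two compounds cannot be told apart in this cell assay. Nothing available explains this result or shows what the chloro group does at this position.

As far as these compounds go, it remains open whether the remaining chloro group matters, which a plain phenyl ring would test. Also open, from the compounds shown here alone, is how a fluoro, an amine or a carboxylic acid would fare at the same place, and whether the swap reads the same in compound 2.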